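An ether side-chain isomer and its expected permeability

The source may report more compounds than this note shows. Statements on the series, on what has been measured and on what is new or still open speak of the compounds shown alone.

Measured compounds:
compound 1, `COC(C)(C)[C@@H](O)C(=O)N1[C@H](C(=O)NCc2cc(Cl)ccc2-n2cnnn2)C[C@@H]2C[C@@H]21`, gives 16 10^-6 cm/s in an ADME assay on Caco-2 cells (Homo sapiens) for permeability, read by LC-MS, in the apical to basolateral direction, with a stated time of 60 min, at pH 6.5; on this read-out lower numbers stand for lower permeability and higher numbers for higher permeability
compound 2, `O=C(NCc1cc(Cl)ccc1-n1cnnn1)[C@@H]1[C@@H]2C[C@@H]2CN1C(=O)[C@H](O)Cc1ccccn1`, gives 0.62 10^-6 cm/s in this assay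
compound 3, `CCCC[C@@H](O)C(=O)N1[C@@H]2C[C@@H]2C[C@H]1C(=O)NCc1cc(Cl)ccc1-n1cnnn1`, gives 35 10^-6 cm/s in this assay

Compound 1 stands second highest of the three in this assay. Compound 3 gives the higher number, and that gap lies beyond the scatter; compound 2 gives a far lower number, also beyond the scatter. Compound 4, `CC(C)(C)OC[C@@H](O)C(=O)N1[C@H](C(=O)NCc2cc(Cl)ccc2-n2cnnn2)C[C@@H]2C[C@@H]21`, differs from compound 1 in one place: (tert-butoxy)methyl in place of 1-methoxy-1-methylethyl on a saturated chain carbon bound to a carbonyl carbon and an oxygen on a saturated carbon. Going by the values given here, no pair of measured compounds shows this change, so its size is unknown here. The group that leaves and the group that enters each carry one hydrogen-bond acceptor, no donors and no net charge, and the step of a 1.1-fold higher number from compound 1 to compound 4 (0.05 log units; within the scatter) is expected to be small, in neither direction beyond the scatter. Compound 4 is expected to give 18 10^-6 cm/s, between 8 10^-6 cm/s and 40 10^-6 cm/s.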

Compound 4, apparent permeability: 4.5 10^-6 cm/s
Beside the measured number, compound 4's estimate is 4.0-fold (0.60 log units) above it, and the stated range ends above it.
By their numbers in this assay, from the lowest: compound 2; then compound 4; then compound 1; then compound 3.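

In this assay, (tert-butoxy)methyl in place of 1-methoxy-1-methylethyl on a saturated chain carbon bound to a carbonyl carbon and an oxygen on a saturated carbon gives a 3.6-fold lower number from compound 1 to compound 4 (0.55 log units; beyond the scatter) on the shared core. This position therefore separates two groups with the same counted hydrogen-bond donors, acceptors and net charge, so those counts alone do not set the number here. Nothing measured here accounts for the step.

The compounds shown leave open how an amine or a carboxylic acid at this place would read in this assay. They also leave open how a longer ether chain would read there.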